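A few compounds are considered here, and "the series" means these few. Any claim that something is new, unique, unknown or untested is made for them only; others in the source may bear on it.

In a functional assay on MCF7 cells (Homo sapiens) for cytotoxicity (on this read-out lower numbers stand for an effect already at smaller amounts and higher numbers for an effect only at larger amounts of compound), three compounds have been measured so far. Compound 1 `COc1cc(/C=C/c2ccc(C(C)C)cc2)cc(OC)c1OC` gives 18.4 uM, the highest number of the three. Compound 2 `COc1cc(/C=C\c2ccc(C(C)(C)C)cc2)cc(OC)c1OC` gives 1.57 uM, and compound 3 `COC(=O)/C(=C/c1cccc(OC)c1)c1cc(OC)c(OC)c(OC)c1` gives 1.3 uM. Both of these numbers lie lower than that of compound 1 by more than the usual scatter of repeated measurements, and they sit within that scatter of each other. On this read-out, compound 1 therefore needs the largest amount to produce its effect.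

Compound 4 `CCCOc1ccc(/C=C/c2cc(OC)c(OC)c(OC)c2)cc1` has not yet been measured. It keeps the core of compound 1 and changes a single group: propoxy in place of isopropyl on an aromatic carbon. Propoxy stands in place of isopropyl on an aromatic carbon, para to a large group.

Going by the values given here, no two measured compounds differ in just one place, so the data give no direct measure of this swap. Compound 2 and compound 3 each differ from compound 1 in more than this one place, which makes them poor guides. The expectation in this assay is therefore a small downward shift and no step beyond the scatter. The expected step is a 1.3-fold lower number from compound 1 to compound 4 (0.12 log units; within the scatter), an estimate that stays within the scatter. Compound 4 is expected at about 14 uM, with an estimated range from 4 uM to 45 uM.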

Compound 4, concentration for half-maximal effect: 12.5 uM
Beside the measured number, compound 4's estimate is 1.1-fold (0.05 log units) above it; the range from low to high includes it.
By their numbers in this assay, from the lowest: compounds 3 and 2 (each within the scatter of the next); then compounds 4 and 1 (each within the scatter of the next).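

Going by these compounds alone, the pair gives the first direct reading of a single change at this position: with propoxy in place of isopropyl on an aromatic carbon, para to a large group, this assay shows a 1.5-fold lower number from compound 1 to compound 4 (0.17 log units; within the scatter). The swap is not a trivial one on paper, since propoxy has 4 heavy atoms, including an oxygen, and 1 hydrogen-bond acceptor, while isopropyl has 3 heavy atoms, all carbon, and no acceptor, yet this difference in structure comes with no step beyond the scatter on this read-out. No measurement at hand speaks to what lies behind this result.

Within the data shown here, with only this one swap to read, it remains open whether a longer chain such as pentyloxy, or an amine or a carboxylic acid in the same place, would also stay within the scatter or would produce a clear step. The steps from compound 1 to compound 2 and to compound 3 cannot be read, since each of those pairs differs in more than one place.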